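A few compounds are considered here, and "the series" means these few. Any claim that something is new, unique, unknown or untested is made for them only; others in the source may bear on it.

Compound 1 `Nc1cc(N)c2nc(-c3ccccc3)c(Oc3ccc(Cl)c(Cl)c3)nc2c1`: < 100000 nM
Compound 2 `CCOC(=O)[C@H](CCC(=O)O)NC(=O)c1ccc(Sc2nc3cc(N)cc(N)c3nc2-c2ccccc2)cc1`: < 100000 nM
Compound 3 `COc1cc(CNc2nc3cc(N)cc(N)c3nc2-c2ccccc2)cc(OC)c1OC`: < 50200 nM

All three compounds share one core and differ only in the group hung on it. They were tested in a functional assay on 786-0 cells (Homo sapiens) for inhibition, read by sulforhodamine B assay, with a stated time of 48 h; on this read-out lower numbers stand for higher toxicity in this test and higher numbers for lower toxicity in this test. In this assay compound 1 gives < 100000 nM, which is a limit of the assay and not a measured number. Compound 2 gives < 100000 nM, again a limit. Compound 3 gives < 50200 nM, also a limit. So compound 1 stands at the limit of < 100000 nM in this assay, at which 2 of the 3 values shown sit, together with compound 2, while compound 3 sits at the limit of < 50200 nM in this assay, at which 1 of the 3 values shown sits. Among the compounds with values here, no pair among the three therefore shows a measured step, and nothing tells how far apart the three actually lie.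

Compound 4 `COc1ccc(Sc2nc3cc(N)cc(N)c3nc2-c2ccccc2)cc1` has not yet been tested. It differs from compound 1 by (4-methoxyphenyl)sulfanyl in place of 3,4-dichlorophenoxy on an aromatic carbon. Within the data shown here, with no measured step to lean on, the expected change is a step that the limit leaves unreadable from compound 1 to compound 4, with no direction that can be trusted beyond the scatter, and a fair chance that the assay again reports only a limit. For compound 4 the expected value in this assay is 30000 nM, within 5000 nM to 100000 nM.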

Compound 4, concentration lethal to 50% of the cells: 70800 nM
Compound 4: middle estimate off by 2.4-fold (0.37 log units), on the low side, and the stated range covers the measured number.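

No step can be read from compound 1 to compound 4, because compound 1 is known only as a limit and not as a measured number: the limit of < 100000 nM in this assay, at which 2 of the 4 values shown sit.

The compounds shown leave open whether (4-methoxyphenyl)sulfanyl in place of 3,4-dichlorophenoxy on an aromatic carbon changes the lethal concentration at all, and if so, in which direction.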